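The source may hold more compounds than are shown below. What is called first, only, known or untested is meant among the compounds shown, and "the series" means these compounds.

Compound 1 `Clc1ccc(-c2cc(-c3ccco3)nc(-c3ccc(Cl)s3)c2)o1` gives 23.1% in an assay on isolated protein for inhibition of DNA topoisomerase 1 (Homo sapiens), with a stated time of 30 min, tested at 100 uM; on this read-out higher numbers stand for more inhibition at the one concentration tested (going by the name of the read-out) and lower numbers for less inhibition. Compound 2 `Cc1ccc(-c2cc(-c3ccc(Cl)o3)cc(-c3ccc(Cl)s3)n2)cc1` gives 14.2% in this assay; this is the lowest of the two numbers, though the step of a number 8.9 percentage points lower from compound 1 to compound 2 (within the scatter) stays within the scatter. Compound 3 `Clc1ccc(-c2cc(-c3ccc(Cl)o3)cc(-c3ccc(Cl)s3)n2)cc1` differs from compound 2 by chloro in place of methyl on an aromatic carbon. Among the compounds with values here, no measured step swaps one of these groups for the other, so only the small step from compound 1 to compound 2 offers any guide. Compound 3 is therefore expected to sit close to compound 2, with an estimated step of a number 2.8 percentage points higher from compound 2 to compound 3 (within the scatter) in this assay. The expected value for compound 3 is 17%, between 5% and 32%.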

Compound 3, a percentage reported as inhibition, at one concentration (the size of the read-out at that concentration, not a potency): 2.2%
Beside the measured number, compound 3's estimate is 14.8 percentage points above it; measured number outside the range, below it.
By their numbers in this assay, from the lowest: compound 3; then compounds 2 and 1 (each within the scatter of the next).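

In this assay, within the data shown here, the change from 4-methylphenyl to 4-chlorophenyl gives a number 12 percentage points lower from compound 2 to compound 3 (beyond the scatter) and is the first change of a single group here to go beyond the scatter. The group carried on this six-membered ring therefore matters, even though it differs by only one heavy atom. Putting 4-chlorophenyl in place of furan-2-yl gives a number 20.9 percentage points lower from compound 1 to compound 3 (beyond the scatter) and is the largest step among these compounds. Nothing available explains why the number falls. As far as these compounds go, whether an amine or a methoxy group in the same place would raise the number or lower it further remains open.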